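The compounds below may be only part of what the source reports. "The series", "measured", "known", "first", "only" and "open" are said of these compounds alone.

Measured compounds:
- compound 1 `C/C=C/C(=O)N(Cc1ccc(OC)c(C)c1)c1cc(OC)c(OC)c(OC)c1`: 32900 nM
- compound 2 `C/C=C/C(=O)N(Cc1ccc(OC)c(Br)c1)c1cc(OC)c(OC)c(OC)c1`: 10500 nM
- compound 3 `COc1ccc(CN(C(=O)CN=[N+]=[N-])c2cc(OC)c(OC)c(OC)c2)cc1O`: 160 nM

In a functional assay on KYSE-450 cells (Homo sapiens) for inhibition, read by MTT assay, with a stated time of 48 h (on this read-out lower numbers stand for stronger inhibition and higher numbers for weaker inhibition), compound 3 gives the lowest number of the three, with compound 2 the nearest and compound 1 the furthest, both beyond the scatter. Compound 4 `C/C=C/C(=O)N(Cc1ccc(OC)c(O)c1)c1cc(OC)c(OC)c(OC)c1` has not been measured. The change from compound 3 to compound 4 is prop-1-en-1-yl in place of azidomethyl on a carbonyl carbon.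

For the measured compounds named here, only one measured step exists, a 3.1-fold lower number from compound 1 to compound 2 (0.50 log units; beyond the scatter), and it concerns a substituent on an aromatic carbon, not the carbonyl carbon where compound 4 differs from compound 3; it therefore does not bear on this change. Going by the values given here, compounds 1 and 2 carry the prop-1-en-1-yl group that enters in compound 4, and both give far higher numbers in this assay than compound 3; compound 4, however, also keeps the hydroxyl of compound 3, which neither compound 1 nor compound 2 has, and no step isolates that group. The expectation is therefore that compound 4 gives a higher number than compound 3, by a step estimated at a 19-fold higher number from compound 3 to compound 4 (1.27 log units; beyond the scatter), with wide uncertainty. The estimate for compound 4 is 3000 nM, with a range from 300 nM to 30000 nM.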

Compound 4, half-maximal inhibitory concentration: 67 nM
Compound 4: middle estimate off by 45-fold (1.65 log units), on the high side, and the stated range ends above it.
By their numbers in this assay, from the lowest: compound 4; then compound 3; then compound 2; then compound 1.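

In this assay, prop-1-en-1-yl on the carbonyl carbon keeps the number low once the hydroxy group is present (a 2.4-fold lower number from compound 3 to compound 4 (0.38 log units; beyond the scatter)), so azidomethyl is not required for a low number among these compounds. The high numbers of compound 1 and compound 2 therefore go with the group on the aromatic carbon and not with prop-1-en-1-yl: hydroxy in place of bromo (a 160-fold lower number from compound 2 to compound 4 (2.20 log units; beyond the scatter)) and hydroxy in place of methyl (a 490-fold lower number from compound 1 to compound 4 (2.69 log units; beyond the scatter)) are both large steps. Nothing available explains the size of these steps.

The compounds shown leave open whether a longer chain or an amine on the carbonyl carbon would keep the number this low. They also leave open whether an amine or a carboxylic acid on the aromatic carbon could stand in for the hydroxy group.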